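The source may hold more compounds than are shown below. What is called first, only, known or untested is meant among the compounds shown, and "the series" means these compounds.

Compound 1, drawn as `O=C(O)CCCNC(=O)CCCSC[C@H](NC(=O)OCc1ccccc1)C(=O)Nc1ccccc1`, carries an acid at the end of its chain. In an assay for inhibition of NAD-dependent protein deacylase sirtuin-6 (Homo sapiens), read by HPLC, with stated times of 15 min and 1 h, tested at 333 uM (a higher number here means more inhibition at the concentration tested (going by the name of the read-out), a lower number less inhibition), compound 1 gives 35%. Compound 2, `O=C(O)CCNC(=O)CCCSC[C@H](NC(=O)OCc1ccccc1)C(=O)Nc1ccccc1`, is the same molecule with a shorter acid end, and in this assay compound 2 gives 43%. Within the data shown here, the only step measured so far is a number 8 percentage points higher from compound 1 to compound 2 (within the scatter), so compound 2 and compound 1 cannot be told apart on these numbers.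

Compound 3, `CCCCCCNC(=O)CCCSC[C@H](NC(=O)OCc1ccccc1)C(=O)Nc1ccccc1`, goes a different way: the acid is gone and a plain hydrocarbon chain takes its place. The change is butyl in place of carboxy on a saturated chain carbon, two bonds along the chain from an amide-type nitrogen. Among the measured compounds shown here, the one measured step, shortening the acid end, bears on it only loosely, because it kept the acid while a number 8 percentage points higher from compound 1 to compound 2 (within the scatter) turned out small. For the measured compounds named here, no measured pair removes the acid altogether, so there is no direct guide to the size or direction of the step in this assay.

The step is therefore expected to be a number 8 percentage points lower from compound 2 to compound 3 (within the scatter), with wide uncertainty. Compound 3 is estimated at 35%, with a range from 10% to 60%.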

Compound 3, a percentage reported as inhibition, at one concentration (the size of the read-out at that concentration, not a potency): "not active" (no number reported)
For compound 3 the study gives words and no number; no gap can be computed for the estimate.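

In this assay, among these compounds, compound 3 is reported only in words, as "not active" (no number reported), and no step from compound 2 to compound 3 can be read. Nothing measured here offers an explanation for this result. The compounds shown leave open how much inhibition, if any, remains when butyl replaces carboxy.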